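The compounds below may be only part of what the source reports. "The series", "measured", "known", "first", "only" and "open" are said of these compounds alone.

Measured so far in a functional assay on SW480 cells (Homo sapiens) for antiproliferative activity, read by sulforhodamine B assay, with a stated time of 48 h; on this read-out lower numbers stand for stronger inhibition and higher numbers for weaker inhibition:
- compound 1 `COc1ccc(OC)c(/C=C/C(=O)/C=C(O)/C=C/c2cc(OC)ccc2OC)c1`: 15600 nM
- compound 2 `COc1cccc(/C=C/C(=O)C(=Cc2ccc(F)cc2)C(=O)/C=C/c2cccc(OC)c2OC)c1OC`: 1040 nM
- compound 3 `COc1cc(OC)c(C=C(C(=O)/C=C/c2cccc(OC)c2OC)C(=O)/C=C/c2cccc(OC)c2OC)c(OC)c1`: 840 nM

Compound 3, at 840 nM, cannot be told apart from compound 2, at 1040 nM, on these numbers. Both values are far smaller than that of compound 1, at 15600 nM.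

The next compound to consider is compound 4 `COc1cc(C=C(C(=O)/C=C/c2cccc(OC)c2OC)C(=O)/C=C/c2cccc(OC)c2OC)cc(OC)c1O`, which differs from compound 3 in one group: 4-hydroxy-3,5-dimethoxyphenyl in place of 2,4,6-trimethoxyphenyl on a double-bonded chain carbon bound to a double-bonded chain carbon. In words, 4-hydroxy-3,5-dimethoxyphenyl takes the place of 2,4,6-trimethoxyphenyl on a double-bonded chain carbon bound to a double-bonded chain carbon.

Among the measured compounds shown here, only one measured step changes the group at this place: a 1.2-fold lower number from compound 2 to compound 3 (0.09 log units; within the scatter). That exchange of 4-fluorophenyl for 2,4,6-trimethoxyphenyl left the number within the scatter, which suggests that the read-out may tolerate changes here. For the measured compounds named here, this is a single step, however, and no measured step brings in a group with a hydrogen-bond donor at this place, so the range must stay wide.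

The expected change in this assay is therefore no step beyond the scatter, in either direction: a 1.1-fold higher number from compound 3 to compound 4 (0.03 log units; within the scatter).

The estimated value for compound 4 is 900 nM, with an expected range from 350 nM to 2300 nM.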

Compound 4, half-maximal inhibitory concentration: 420 nM
The estimate for compound 4 lay 2.1-fold (0.33 log units) above the measured number, within the range that was stated.
By their numbers in this assay, from the lowest: compounds 4, 3 and 2 (each within the scatter of the next, the first and the last beyond it); then compound 1.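

In this assay, this place now carries a group with a hydrogen-bond donor, 4-hydroxy-3,5-dimethoxyphenyl, and the step of a 2.0-fold lower number from compound 3 to compound 4 (0.30 log units; within the scatter) stays within the scatter, so this exchange for 2,4,6-trimethoxyphenyl cannot be called a real gain. The step of a 2.5-fold lower number from compound 2 to compound 4 (0.39 log units; beyond the scatter) is the only one at this place that goes beyond the scatter, though modestly, which shows that the group on this double-bonded chain carbon can move the number when 4-hydroxy-3,5-dimethoxyphenyl replaces 4-fluorophenyl. No measurement available here accounts for either step.

The two groups in compound 3 and compound 4 differ in both their hydroxy group and the arrangement of their methoxy groups, so the contribution of the hydroxy group cannot be separated out, and a comparison with 3,4,5-trimethoxyphenyl at this place would be needed to do that. It also remains open how the number would respond to an amine or a carboxylic acid on the phenyl group here, since every group shown at this place carries only fluorine, methoxy or hydroxy substituents.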